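The source may hold more compounds than are shown below. What is called first, only, known or untested is meant among the compounds shown, and "the series" means these compounds.

Compound 1, `O=C(NCCO)c1cc2ccc(OCc3ccccc3)cc2oc1=O`, gives 14200 nM in a functional assay on HeLa cells (Homo sapiens) for cytotoxicity, read by MTT assay, with a stated time of 72 h; on this read-out lower numbers stand for stronger inhibition and higher numbers for weaker inhibition. Compound 2, `CCN(CC)c1ccc2cc(C(=O)NCCO)c(=O)oc2c1`, is recorded in this assay only as a limit, > 100000 nM. The step of an at least 7.0-fold higher number from compound 1 to compound 2 (0.84 log units; beyond the scatter) is thus open at its upper end, because it runs into (the limit of > 100000 nM in this assay, at which 1 of the 2 values shown sits). Compound 3, `CCN(CC)c1ccc2cc(C(=O)NC3CC3)c(=O)oc2c1`, differs from compound 2 by cyclopropyl in place of 2-hydroxyethyl on an amide-type nitrogen, the change sitting on the amide-type nitrogen whose other neighbour is the carbonyl carbon. For the measured compounds named here, no measured step touches this position: the single measured step concerns the substituent on the aromatic carbon, so the two known values say nothing about how the amide substituent moves the numbers in this assay. With compound 2 standing at a limit, compound 3 is expected to give about 100000 nM, within 30000 nM to 300000 nM, a step of a number no higher from compound 2 to compound 3 (the limit leaves the size open), and it would most likely again be reported only as a limit.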

Compound 3, half-maximal inhibitory concentration: > 100000 nM
Compound 3: only a limit was reported; the forecaster's own chance of this, stated with the estimate: 60%; the middle value lies on the limit itself.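

No step from compound 2 to compound 3 can be read, because both compounds are recorded only as a limit: the limit of > 100000 nM in this assay, at which 2 of the 3 values shown sit.

The compounds shown leave open whether cyclopropyl in place of 2-hydroxyethyl on the amide-type nitrogen changes the numbers at all in this assay.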